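Fluoro for methyl on the benzyl ether: a second instance

The source may report more compounds than this note shows. Statements on the series, on what has been measured and on what is new or still open speak of the compounds shown alone.

Measured so far in a functional assay on HT-29 cells (Homo sapiens) for inhibition, read by MTT assay, with a stated time of 48 h; a lower number here means a stronger inhibitor, a higher number a weaker inhibitor:
compound 1 `Cc1ccc(COc2ccc(C(=O)NC(=S)Nc3ccc(C)c(-c4nc5ccccc5[nH]4)c3)cc2)cc1` gives 14200 nM
compound 2 `Cc1ccc(NC(=S)NC(=O)c2ccc(OCc3ccc(F)cc3)cc2)cc1-c1nc2ccccc2[nH]1` gives 1910 nM
compound 3 `Cc1ccc(COc2ccc(C(=O)NC(=O)Nc3ccc(Cl)c(-c4nc5ccccc5[nH]4)c3)cc2)cc1` gives 2950 nM

Compound 1 and compound 2 share a core and differ only by fluoro in place of methyl on an aromatic carbon. That change gave a 7.4-fold lower number from compound 1 to compound 2 (0.87 log units; beyond the scatter). Compound 3 has a different core; the difference between the core of compound 3 and the core of compound 1 is not broken down here. Compound 3 and compound 2 lie within the scatter of each other, while compound 3 and compound 1 lie beyond it.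

Compound 4 `O=C(NC(=O)c1ccc(OCc2ccc(F)cc2)cc1)Nc1ccc(Cl)c(-c2nc3ccccc3[nH]2)c1` is not yet measured. It relates to compound 3 by fluoro in place of methyl on an aromatic carbon, the same change as from compound 1 to compound 2, and at the same place. Since the change occurs only once among measured compounds, and on a different core, the step is expected to be in the same direction but smaller than the earlier one; this rests on compound 1 and compound 2 through a 7.4-fold lower number from compound 1 to compound 2 (0.87 log units; beyond the scatter) and on compound 3 through 2950 nM. The estimated step is a 3.7-fold lower number from compound 3 to compound 4 (0.57 log units; beyond the scatter). Compound 4 is expected to give about 800 nM in this assay, plausibly between 250 nM and 2500 nM.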

Compound 4, half-maximal inhibitory concentration: 730 nM
Beside the measured number, compound 4's estimate is 1.1-fold (0.04 log units) above it, and the stated range covers the measured number.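

Going from 4-methylbenzyl to 4-fluorobenzyl on the core of compound 3 gave a 4.0-fold lower number from compound 3 to compound 4 (0.61 log units; beyond the scatter) in this assay and so ran in the same direction as on the core of compound 1. The two steps do not separate in size: the same change on two cores in this assay, a 7.4-fold lower number (0.87 log units; beyond the scatter) from compound 1 to compound 2 and a 4.0-fold lower number (0.61 log units; beyond the scatter) from compound 3 to compound 4, 1.8-fold (0.26 log units) apart, within the scatter of two such steps. Going by these compounds alone, this shows that the change carried over between these two cores in this one cell assay, but with only two pairs it does not show that the step has a fixed size, that it would hold on any further core, or why the number falls.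

The cores of compound 1 and compound 3 differ in more than one place, and no pair shown isolates either difference or tells how each one alone acts on the step. Also open, on these data alone, is how that same position would respond to a group other than methyl or fluoro, such as methoxy, trifluoromethyl or an amine.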